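A few compounds are considered here, and "the series" means these few. Any claim that something is new, unique, unknown or untested is made for them only; others in the source may bear on it.

Compound 1 `COc1ccc2nc(C)cc(NCc3ccc(F)cc3F)c2c1` and compound 2 `COc1ccc2nc(C)cc(NCc3c(F)cccc3F)c2c1` share the same atoms, joined differently, and the difference between their two cores is not broken down here. In a functional assay on MCF-10A cells (Homo sapiens) for antiproliferative activity, with a stated time of 48 h (a higher number here means that more compound is needed for the effect, a lower number that less compound is needed), compound 1 gives 15000 nM. In this assay compound 2 gives 13600 nM, which lies within the scatter of the number for compound 1. Compound 3 `COc1ccc2nc(C)cc(NCc3ccc(F)cc3C(F)(F)F)c2c1` differs from compound 1 in one place: trifluoromethyl in place of fluoro on an aromatic carbon. In this assay compound 3 gives 4200 nM, and the step of a 3.6-fold lower number from compound 1 to compound 3 (0.55 log units; beyond the scatter) is therefore beyond the scatter.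

Compound 4 `COc1ccc2nc(C)cc(NCc3c(F)cccc3C(F)(F)F)c2c1` has not yet been measured. It differs from compound 2 in one place: trifluoromethyl in place of fluoro on an aromatic carbon. The place lines for this change and for the change from compound 1 to compound 3 read the same word for word, so the two changes are the same change, made on two cores whose difference is not broken down here. Among the compounds shown it occurs twice in all.

For the measured compounds named here, the step of a 3.6-fold lower number from compound 1 to compound 3 (0.55 log units; beyond the scatter) is the only measured instance of this change, and since compound 1 and compound 2 give numbers within the scatter of each other, a step of similar size is expected in this assay. The estimate for compound 4 means a 3.4-fold lower number from compound 2 to compound 4 (0.53 log units; beyond the scatter). Compound 4 is thus expected to give about 4000 nM in this assay, with a range from 2000 nM to 8000 nM.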

Compound 4, half-maximal effective concentration: 14000 nM
For compound 4 the middle estimate is 3.5-fold (0.54 log units) below the measured one, and the stated range ends below it.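

In this assay, trifluoromethyl in place of fluoro on an aromatic carbon did not carry over from one core to the other: the same change on two cores in this assay, a 3.6-fold lower number (0.55 log units; beyond the scatter) from compound 1 to compound 3 and a 1.0-fold higher number (0.01 log units; within the scatter) from compound 2 to compound 4, 3.7-fold (0.57 log units) apart, beyond the scatter of two such steps. With a 1.0-fold higher number from compound 2 to compound 4 (0.01 log units; within the scatter), the lower number seen on the core of compound 1 does not return on the core of compound 2, even though compound 1 and compound 2 themselves give numbers within the scatter of each other. This shows that the step measured on one core could not be transferred to the other in this series, and that matching numbers for two parent compounds were no guide to it; it does not show what about the two cores sets the steps apart, and two instances of the change give no rule for any further core.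

On these data alone, whether a chloro group or a nitrile at the same place would follow the core of compound 1, the core of compound 2 or neither remains open. As far as these compounds go, it also remains open whether the two cores would part in the same way with a change elsewhere on the molecule, such as a longer chain in place of the methyl group on the shared core.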